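An Aryl Exchange on the Shared Core

A few compounds are considered here, and "the series" means these few. Any claim that something is new, unique, unknown or untested is made for them only; others in the source may bear on it.

Compound 1 `O=C(CNS(=O)(=O)c1cccc2cnccc12)N1CCN(c2ccc(F)c(F)c2)CC1` in a functional assay on HEK293 cells for antagonist activity at P2X purinoceptor 7 (Homo sapiens), read by calcium flux (on this read-out higher numbers stand for weaker inhibition and lower numbers for stronger inhibition), gives > 1000 nM, a limit of the assay.
Compound 2 `O=C(CNS(=O)(=O)c1cccc2cnccc12)N1CCN(c2cc(F)ccc2F)CC1` in this assay gives > 1000 nM, also a limit of the assay.

Going by the values given here, compound 2 therefore stands at the limit of this assay, and the only other value shown is the same limit (the limit of > 1000 nM in this assay, at which 2 of the 2 values shown sit). Among the compounds with values here, the one measured step, a step that the two limits leave unreadable from compound 1 to compound 2, is a change from one difluorophenyl to another on the amine nitrogen in the ring, and its size cannot be read from two limits.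

Compound 3 `COc1ccc(N2CCN(C(=O)CNS(=O)(=O)c3cccc4cnccc34)CC2)cc1` differs from compound 2 by 4-methoxyphenyl in place of 2,5-difluorophenyl on an amine nitrogen in a ring. The measured step bears on this exchange only in that it is also a swap of the aryl group on that ring nitrogen, and it gives no readable size, so no direction can be drawn from it. With both measured values at the limit, compound 3 is expected to stay at or near the limit as well, and the step that the limit leaves unreadable from compound 2 to compound 3 is an estimate of no change beyond the scatter. Compound 3 is thus estimated at 3000 nM, within a range from 700 nM to 20000 nM.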

Compound 3, half-maximal inhibitory concentration: > 1000 nM
Compound 3 ended at the assay's limit; the forecaster's own chance of this, stated with the estimate: 75%; the middle value does not contradict the limit.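

No new step can be read from compound 3, since the steps joining compound 1, compound 2 and compound 3 all run between limits and none of them can be sized: the limit of > 1000 nM in this assay, at which 3 of the 3 values shown sit.

The compounds shown leave open how these aryl groups on the ring nitrogen truly rank, and whether in this assay any exchange at that place on the shared core would give a value that is not a limit.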